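A Difluorinated Phenyl Ring on a Cytotoxic Amide

The source may hold more compounds than are shown below. What is called first, only, known or untested is meant among the compounds shown, and "the series" means these compounds.

Of the compounds shown here, two with a shared core have been tested in a functional assay on PC-3 cells (Homo sapiens) for cytotoxicity, read by MTT assay, with a stated time of 72 h; a lower number here means a stronger inhibitor, a higher number a weaker inhibitor. Compound 1 `Cc1ccc(-c2ccnc(C(=O)Nc3ccc(Oc4ccnc5[nH]ccc45)cc3)c2)cc1` returns only a limit of the assay: in this assay compound 1 gives > 10000 nM. For the measured compounds named here, compound 2 `O=C(Nc1ccc(Oc2ccnc3[nH]ccc23)c(F)c1)c1ccc(-c2ccccc2)cn1` is the one compound with a number: in this assay compound 2 gives 760 nM. Going by the values given here, compound 2 therefore stands as the only numerical reading, the other value being a limit (the limit of > 10000 nM in this assay, at which 1 of the 2 values shown sits), and since compounds 1 and 2 differ in more than one place, no measured step between them can be drawn.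

Compound 3 `O=C(Nc1ccc(Oc2ccnc3[nH]ccc23)c(F)c1)c1ccc(-c2ccc(F)cc2F)cn1` has not yet been measured. It differs from compound 2 by 2,4-difluorophenyl in place of phenyl on an aromatic carbon. No measured step of this kind exists among the compounds shown, so the change from compound 2 to compound 3 is expected to stay within the usual scatter, with no clear direction, which is what a 1.2-fold lower number from compound 2 to compound 3 (0.07 log units; within the scatter) expresses. Compound 3 is accordingly estimated to give 650 nM in this assay, with a likely range from 200 nM to 2200 nM.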

Compound 3, half-maximal inhibitory concentration: 4720 nM
Estimate against measurement, compound 3: 7.3-fold (0.86 log units) below; the measured number lies above the stated range.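

In this assay, this position, on an aromatic carbon of the six-membered aromatic ring with 1 nitrogen and para to a large group, proves sensitive to substitution: replacing phenyl with 2,4-difluorophenyl gives a 6.2-fold higher number from compound 2 to compound 3 (0.79 log units; beyond the scatter). For the compounds shown here, the earlier compounds offered no measured step at all, so this is the first reading of a single change here, and it shows that adding two fluorine atoms, with no change in the counted hydrogen-bond donors, acceptors or net charge, is enough to move the number beyond the scatter. Compound 1 remains a limit of the assay and enters no step: the limit of > 10000 nM in this assay, at which 1 of the 3 values shown sits.

Whether one fluorine alone accounts for the step stays open, since neither 2-fluorophenyl nor 4-fluorophenyl is among the compounds shown, and so does the reading of a phenyl ring carrying a methoxy group or an amine at this position. The compounds shown also give no measured property that would explain the step, so its cause remains unknown.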